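Para-substituent swap on the aryl-oxadiazole series

The source may hold more compounds than are shown below. What is called first, only, known or untested is meant among the compounds shown, and "the series" means these compounds.

Measured compounds:
compound 1 `O=C(CCc1nnc(-c2ccccc2)o1)c1ccccc1` — 29.4%
compound 2 `O=C(CCc1nnc(-c2ccc(Cl)cc2)o1)c1ccccc1` — 81.5%

In a functional assay on the whole organism (strain Wistar) for inhibition, with Rattus norvegicus as the target, with stated times of 30 min and 3 h, at a dose of 20 mg/kg by the oral route (on this read-out higher numbers stand for more inhibition at the one dose given (going by the name of the read-out) and lower numbers for less inhibition), compound 1 gives 29.4% and compound 2 gives 81.5%. Compound 2 stands highest of the two numbers measured; the nearest is compound 1, and the gap between them, a number 52.1 percentage points higher from compound 1 to compound 2 (beyond the scatter), lies beyond the scatter. Going by the values given here, that single step, chloro in place of hydrogen on an aromatic carbon, is the only measured step.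

Compound 3 `O=C(CCc1nnc(-c2ccc([N+](=O)[O-])cc2)o1)c1ccccc1` is not yet measured. Its change from compound 2 is nitro in place of chloro on an aromatic carbon. Among the compounds with values here, no measured step covers a swap of one substituent for another at this position; the only step that bears on it, from compound 1 to compound 2, shows that putting a group on this aromatic carbon in place of hydrogen raised inhibition by a large amount. Because a number 52.1 percentage points higher from compound 1 to compound 2 (beyond the scatter) shows that the number for the substituted ring is higher than that for the bare one, compound 3 is expected to stay nearer compound 2 than compound 1, with a step of about a number 11.5 percentage points lower from compound 2 to compound 3 (beyond the scatter) that may fall within the scatter. For compound 3 the expected inhibition is 70%, in the range 45% to 90%.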

Compound 3, a percentage reported as inhibition, in the whole organism at one dose (the size of the read-out at that dose, not a potency): 62.7%
Compound 3: middle estimate off by 7.3 percentage points, on the high side; measured number inside the range.
By their numbers in this assay, from the lowest: compound 1; then compound 3; then compound 2.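

In this assay, the gain over the bare ring is not tied to chloro: nitro on the same aromatic carbon, para to a large group, also lifts the number (a number 33.3 percentage points higher from compound 1 to compound 3 (beyond the scatter)). The two substituents are still not interchangeable at this carbon, since the swap of chloro for nitro costs part of that gain (a number 18.8 percentage points lower from compound 2 to compound 3 (beyond the scatter)), so the identity of the group matters here and not only the replacement of hydrogen. The data shown hold no measurement that bears on why chloro and nitro differ in this read-out, and the two groups can only be ranked, not explained.

With hydrogen, chloro and nitro as the only groups shown at this carbon, it remains open whether an amine, a methoxy group or a carboxylic acid there would keep the number nearer compound 2 or fall back toward compound 1. Also open, going by these compounds, is whether the same substituents would behave alike elsewhere on that ring, and how a longer chain in place of the linker of the shared core would change the picture.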